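A few compounds are considered here, and "the series" means these few. Any claim that something is new, unique, unknown or untested is made for them only; others in the source may bear on it.

Working notes on the series. Among the measured compounds shown here, the core of compound 3 `COc1cc(OC)c2c(=O)cc(C(=O)Nc3ccc(C4CCCCC4)cc3)[nH]c2c1` carries the amide side chain; in an ADME assay on BJ cells (Homo sapiens) for antiproliferative activity, with a stated time of 72 h (a lower number here means that less compound is needed, a higher number that more compound is needed for the effect), compound 3 gives 36200 nM, the only number among the three values shown. Compound 1 `COc1ccc(-c2cc(=O)c3c(OC)cc(OC)cc3n2S(=O)(=O)c2cccc([N+](=O)[O-])c2)cc1` gives only a limit in this assay, > 39600 nM, and no number. Compound 2 `COc1ccc(-c2cc(=O)c3c(OC)cc(OC)cc3n2S(=O)(=O)c2cc(F)c(F)c(F)c2)cc1` likewise gives only a limit in this assay, > 65500 nM. For the measured compounds named here, the one step between measured compounds, a step that the two limits leave unreadable from compound 1 to compound 2, rests on both limits, see the limit of > 39600 nM in this assay, at which 1 of the 3 values shown sits, and (the limit of > 65500 nM in this assay, at which 1 of the 3 values shown sits), and its size cannot be read.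

Compound 4 `COc1cc(OC)c2c(=O)cc(C(=O)Nc3ccc(N4CCN(C)CC4)cc3)[nH]c2c1` differs from compound 3 by 4-methylpiperazin-1-yl in place of cyclohexyl on an aromatic carbon. This change is not on a sulfonyl sulfur, so the step from compound 1 to compound 2 does not bear on it, and that step is unreadable in any case. Going by the values given here, with no measured step as a basis, the expected step of a 1.1-fold higher number from compound 3 to compound 4 (0.04 log units; within the scatter) in this assay is none beyond the scatter, carried with a wide range. Compound 4 is estimated at 40000 nM, between 12000 nM and 130000 nM in this assay.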

Compound 4, half-maximal effective concentration: > 19800 nM
Compound 4 was reported as a limit; the forecaster's own chance of this, stated with the estimate: 35%; the middle value lies beyond the limit too.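

In this assay compound 4 gives only a limit, > 19800 nM, and no number, so the step from compound 3 to compound 4 cannot be read. Left open is whether 4-methylpiperazin-1-yl in place of cyclohexyl changes the number in this assay at all.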